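The compounds below may be only part of what the source reports. "The series", "measured", "known", "first", "only" and "open" are said of these compounds alone.

Among the compounds with values here, compound 2 `CN1CCC(S(=O)(=O)c2ccc3nc(NC(=O)NC(=O)c4cc(N5CCCC5)ccc4Cl)sc3c2)CC1` gives 3.1 in a physicochemical assay for lipophilicity (on this read-out lower numbers stand for lower lipophilicity and higher numbers for higher lipophilicity), the higher of the two values measured so far; compound 1 `Cc1ccnn1-c1ccc(Cl)c(C(=O)NC(=O)Nc2nc3ccc(S(=O)(=O)C4CCN(C)CC4)cc3s2)c1` gives 2.6. The two structures differ in one group, and the step is a number 0.50 log units higher from compound 1 to compound 2 (beyond the scatter). Compound 3 `CN1CCC(S(=O)(=O)c2ccc3nc(NC(=O)NC(=O)c4cc5c(cc4Cl)CCN5C)sc3c2)CC1` departs from compound 2 elsewhere: 5-chloro-1-methyl-2,3-dihydro-1H-indol-6-yl in place of 2-chloro-5-(pyrrolidin-1-yl)phenyl on a carbonyl carbon. Within the data shown here, the one measured step concerns an exchange of a different group, so it bears only loosely on the present change, and compound 3 is expected to move little, a number 0.20 log units lower from compound 2 to compound 3 (within the scatter), possibly with no step beyond the scatter. Compound 3 is therefore estimated at 2.9, within a range from 2.5 to 3.3.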

Compound 3, distribution coefficient: 2.8
Compound 3: the middle estimate sits 0.10 log units above what was measured; the measured number falls inside the stated range.
By their numbers in this assay, from the lowest: compounds 1, 3 and 2 (each within the scatter of the next, the first and the last beyond it).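

In this assay, the exchange on a carbonyl carbon of 2-chloro-5-(pyrrolidin-1-yl)phenyl for 5-chloro-1-methyl-2,3-dihydro-1H-indol-6-yl gives a number 0.30 log units lower from compound 2 to compound 3 (within the scatter) and so separates the two compounds by no more than ordinary measurement noise. Both groups hold one five-membered non-aromatic ring with 1 hetero atom and one six-membered aromatic ring of carbon only, so this rearrangement of those rings gives no step beyond the scatter here. No measured evidence accounts for this result.

The compounds shown leave open what a morpholine or a dimethylamino group in place of the pyrrolidin-1-yl would give in this assay.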